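Swapping a Styryl Arm for a Dimethylaminophenyl Arm

This account rests on a few compounds, and the source may have more. Where it says the series, first, only, none or still open, it means among the compounds named here.

Of the compounds shown here, two sharing one core have been measured in a functional assay on the whole organism for inhibition, with Rattus norvegicus as the target, read by paw edema, with stated times of 30 min and 3 h, at a dose of 10 mg/kg by the oral route; a lower number here means less inhibition, a higher number more inhibition at the dose given (going by the name of the read-out). Compound 1 `COc1ccc(C2CC(C3C(=O)c4ccccc4C3=O)=NC(=O)N2)cc1` gives 22% in this assay. Compound 2 `O=C1N=C(C2C(=O)c3ccccc3C2=O)CC(/C=C/c2ccccc2)N1` gives 18% in this assay, the lowest of the two numbers, although the gap to compound 1 is small: the step of a number 4 percentage points lower from compound 1 to compound 2 (within the scatter) lies within the usual scatter and so shows no real change when 2-phenylethenyl replaces 4-methoxyphenyl on the saturated ring carbon.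

Compound 3 `CN(C)c1ccc(C2CC(C3C(=O)c4ccccc4C3=O)=NC(=O)N2)cc1` has not yet been measured. It differs from compound 2 in a single place: 4-(dimethylamino)phenyl in place of 2-phenylethenyl on a saturated ring carbon

Going by the values given here, only one measured step bears on this change, the one from compound 1 to compound 2, and it exchanged a group on the very same saturated ring carbon without moving the number beyond the scatter. Compound 3 is, in the words of that exchange, closer to compound 1 than to compound 2, and compound 1 gives 22% in this assay. On this basis the expected step of a number 4 percentage points higher from compound 2 to compound 3 (within the scatter) is small and not clearly beyond the scatter. Compound 3 is therefore estimated to give 22% in this assay, with a plausible range from 10% to 34%.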

Compound 3, a percentage reported as inhibition, in the whole organism at one dose (the size of the read-out at that dose, not a potency): 20%
Compound 3: middle estimate off by 2 percentage points, on the high side; the range from low to high includes it.
By their numbers in this assay, from the lowest: compounds 2, 3 and 1 (each within the scatter of the next).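

In this assay the result is a number 2 percentage points higher from compound 2 to compound 3 (within the scatter), so on this saturated ring carbon, a group that brings in nitrogen and a hydrogen-bond acceptor and gives up the double bond outside the aromatic ring cannot be told apart from 2-phenylethenyl. The second comparison concerns an aromatic carbon rather than the saturated ring carbon, and its result is a number 2 percentage points lower from compound 1 to compound 3 (within the scatter), which means that all three compounds now lie within the scatter of one another, with no group on this carbon, and neither of the two groups on the aromatic carbon, standing out from the others. Nothing available accounts for this flat picture.

From the compounds shown here alone, what a much smaller group on the saturated ring carbon, such as methyl, or a carboxylic acid on the aromatic ring would do to the number remains open. A single oral dose also leaves open whether these compounds would separate at other doses, since a percentage at one dose gives the size of the read-out and not a potency.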